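Azido to benzamido on a shared sulfonamide core

This account rests on a few compounds, and the source may have more. Where it says the series, first, only, none or still open, it means among the compounds named here.

Measured compounds:
- compound 1 `NS(=O)(=O)c1cc(-c2nnc(CN3CCC(Cc4ccccc4)CC3)o2)c(Cl)cc1SCc1ccccc1`: 16000 nM
- compound 2 `[N-]=[N+]=NCc1nnc(-c2cc(S(N)(=O)=O)c(SCc3ccccc3)cc2Cl)o1`: 115000 nM

Of the compounds shown here, two share the same core and have been tested in a functional assay on HeLa cells (Homo sapiens) for cytotoxicity, read by MTT assay, with a stated time of 72 h; on this read-out lower numbers stand for stronger inhibition and higher numbers for weaker inhibition. Compound 1 gives 16000 nM. Compound 2 gives 115000 nM, the higher of the two numbers and therefore the weaker inhibition; the gap to compound 1 lies beyond the usual scatter of repeated measurements. Within the data shown here, no single-change step between these two measured compounds is available, so only the two values themselves can be compared.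

Compound 3 `NS(=O)(=O)c1cc(-c2nnc(CNC(=O)c3ccccc3)o2)c(Cl)cc1SCc1ccccc1` has not yet been measured. It differs from compound 2 in one place: benzamido in place of azido on a saturated chain carbon bound to an aromatic carbon. In words, benzamido stands in place of azido on a saturated chain carbon bound to an aromatic carbon. The new group brings a six-membered aromatic ring of carbon only and one hydrogen-bond donor where compound 2 has none at that position.

Among the measured compounds shown here, with no measured step of this kind to lean on, the expectation for compound 3 is cautious: a modest move toward a lower number is expected, a 2.6-fold lower number from compound 2 to compound 3 (0.41 log units; beyond the scatter), leaving it somewhat short of compound 1. Compound 3 is estimated at 45000 nM, within a range of 12000 nM to 130000 nM.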

Compound 3, half-maximal inhibitory concentration: 105000 nM
For compound 3 the middle estimate is 2.3-fold (0.37 log units) below the measured one, and the stated range covers the measured number.
By their numbers in this assay, from the lowest: compound 1; then compounds 3 and 2 (each within the scatter of the next).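

In this assay the change from azido to benzamido on a saturated chain carbon bound to an aromatic carbon gives a 1.1-fold lower number from compound 2 to compound 3 (0.04 log units; within the scatter) and so leaves the read-out effectively unchanged. Among these compounds, this place on the shared core therefore takes on a six-membered aromatic ring of carbon only and a hydrogen-bond donor with no readable shift in the number, something the two earlier values, with no single-change step between them, could not show. Nothing available offers a reason for this flat result.

From the compounds shown here alone, what remains open is whether the ring and the amide hydrogen each count for anything on their own, and a small acetamido group or a free amine at this place would help to tell the two apart. Going by these compounds, it also remains open whether a carboxylic acid, or a longer chain joining the amide to the ring, would move the number in this assay at all when placed on this same core.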